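This account rests on a few compounds, and the source may have more. Where it says the series, first, only, none or still open, it means among the compounds named here.

Measured so far:
Compound 1 `COc1ccc(C(=O)/C=C/c2nc3ccccc3cc2-c2ccc(OC)cc2)cc1`: 6420 nM
Compound 2 `COc1ccc(-c2cc3ccccc3nc2/C=C/C(=O)c2c(OC)cccc2OC)cc1`: 4710 nM

Both numbers come from a functional assay on NCI-H1299 cells (Homo sapiens) for antiproliferative activity, read by XTT assay, with a stated time of 72 h; on this read-out lower numbers stand for stronger inhibition and higher numbers for weaker inhibition. Among the measured compounds shown here, compound 2 and compound 1 stand side by side: the only measured step, a 1.4-fold lower number from compound 1 to compound 2 (0.13 log units; within the scatter), swaps one methoxyphenyl group for another on the carbonyl carbon and does not separate the two compounds.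

Compound 3 `COc1ccc(-c2cc3ccccc3nc2/C=C/C(=O)c2c[nH]c3ccccc23)cc1` is not yet measured. It differs from compound 2 by 1H-indol-3-yl in place of 2,6-dimethoxyphenyl on a carbonyl carbon. The measured step bears on it only loosely: it concerns the same position, but it exchanged two closely related aromatic groups, whereas here a 1H-indol-3-yl with a hydrogen-bond donor replaces a ring carrying two methoxy groups. No shown step covers a change of that kind, so no direction can be read off, and the expectation is a number near that of compound 2, with a wide range.

For compound 3 the estimate in this assay is 5000 nM, between 1500 nM and 16000 nM, which is expected to mean a 1.1-fold higher number from compound 2 to compound 3 (0.03 log units; within the scatter).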

Compound 3, half-maximal inhibitory concentration: > 10000 nM
Compound 3 ended at the assay's limit; the forecaster's own chance of this, stated with the estimate: 5%; at least 2.0-fold (0.30 log units) between middle value and limit.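

Compound 3 ends at a limit of this assay, not at a number: the limit of > 10000 nM in this assay, at which 1 of the 3 values shown sits.

Among the compounds shown here, the earlier swap between two methoxyphenyl groups did not separate compounds 1 and 2, so this is the first sign that the group on the carbonyl carbon can matter: 1H-indol-3-yl in place of 2,6-dimethoxyphenyl gives an at least 2.1-fold higher number from compound 2 to compound 3 (0.32 log units; beyond the scatter). As far as these compounds go, replacing 4-methoxyphenyl with the same group gives an at least 1.5-fold higher number from compound 1 to compound 3 (0.19 log units; that floor lies within the scatter), so that comparison shows no firm loss of activity, and the true size of both steps remains unknown.

The compounds shown cannot tell whether the hydrogen-bond donor of 1H-indol-3-yl or its second ring goes with the weaker result. They also leave open how a plain phenyl or a pyridyl ring on this carbonyl carbon would behave.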